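Swapping the chain amine on compound 3 for cyclohexyl(methyl)amino

A few compounds are considered here, and "the series" means these few. Any claim that something is new, unique, unknown or untested is made for them only; others in the source may bear on it.

In a functional assay on MCF7 cells (Homo sapiens) for antiproliferative activity (on this read-out higher numbers stand for weaker inhibition and lower numbers for stronger inhibition), compound 3 (`CC(C)=CCc1cc(C(=O)Nc2cc3ccc(OCCCNCC(N)=O)c(C)c3oc2=O)ccc1O`) gives 1460 nM and compound 2 (`COC(=O)CNCCCOc1ccc2cc(NC(=O)c3ccc(O)c(CC=C(C)C)c3)c(=O)oc2c1C`) gives 2820 nM at the low end of the series, with only a small gap between them (a 1.9-fold lower number from compound 2 to compound 3 (0.29 log units; within the scatter)). Compound 1 (`CCN(CC)CCCOc1ccc2cc(NC(=O)c3ccc(O)c(CC=C(C)C)c3)c(=O)oc2c1C`) gives 6390 nM and stands clearly higher than both (a 2.3-fold lower number from compound 1 to compound 2 (0.36 log units; beyond the scatter)) and (a 4.4-fold lower number from compound 1 to compound 3 (0.64 log units; beyond the scatter)). Compound 4 (`CC(C)=CCc1cc(C(=O)Nc2cc3ccc(OCCCN(C)C4CCCCC4)c(C)c3oc2=O)ccc1O`) carries cyclohexyl(methyl)amino in place of (carbamoylmethyl)amino (cyclohexyl(methyl)amino in place of (carbamoylmethyl)amino on a saturated chain carbon, three bonds along the chain from an oxygen on an aromatic ring). Like the diethylamino of compound 1, this entering group holds no carbonyl, so the modest step to compound 3 (a 4.4-fold lower number from compound 1 to compound 3 (0.64 log units; beyond the scatter)), read in reverse, is the closest guide. A modest rise is therefore expected in this assay. The estimated step is a 3.4-fold higher number from compound 3 to compound 4 (0.53 log units; beyond the scatter) in this series. For compound 4 the estimated value is 5000 nM within a range of 1800 nM to 13000 nM in this assay.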

Compound 4, half-maximal inhibitory concentration: 1080 nM
Compound 4: the middle estimate sits 4.6-fold (0.67 log units) above what was measured, outside the stated range (below it).
By their numbers in this assay, from the lowest: compounds 4, 3 and 2 (each within the scatter of the next, the first and the last beyond it); then compound 1.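

In this assay, a carbonyl in the chain amine proves unnecessary: cyclohexyl(methyl)amino holds none, yet it stays level with (carbamoylmethyl)amino (a 1.4-fold lower number from compound 3 to compound 4 (0.13 log units; within the scatter)) and gives a lower number than ((methoxycarbonyl)methyl)amino (a 2.6-fold lower number from compound 2 to compound 4 (0.42 log units; beyond the scatter)). Two amines without a carbonyl also separate clearly, with cyclohexyl(methyl)amino giving the lower number against diethylamino (a 5.9-fold lower number from compound 1 to compound 4 (0.77 log units; beyond the scatter)). Nothing available explains this gap. On these data alone, it remains open whether the six-membered ring or the methyl on the nitrogen matters; cyclohexylamino or piperidin-1-yl at this position would help separate the two.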